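Removing the bromo group from compound 2

A few compounds are considered here, and "the series" means these few. Any claim that something is new, unique, unknown or untested is made for them only; others in the source may bear on it.

compound 1 `Clc1ccc(Cn2cc(CCCOc3cccc4cccnc34)nn2)cc1` (11.6 ug/mL)
compound 2 `Brc1ccc(Cn2cc(CCCOc3cccc4cccnc34)nn2)cc1` (25.8 ug/mL)
compound 3 `Clc1ccc(Br)cc1Cn1cc(CCCOc2cccc3cccnc23)nn1` (2.5 ug/mL)

In a functional assay on NCI/ADR-RES cells (Homo sapiens) for inhibition, read by sulforhodamine B assay, with a stated time of 48 h (on this read-out higher numbers stand for weaker inhibition of growth and lower numbers for stronger inhibition of growth), compound 2 has the highest of the three numbers (25.8 ug/mL), which makes it the weakest growth inhibitor of the set. The next compound to consider is compound 4 `c1ccc(Cn2cc(CCCOc3cccc4cccnc34)nn2)cc1`, still unmeasured. It has hydrogen in place of bromo on an aromatic carbon, para to a large group, so 4-bromophenyl becomes phenyl (hydrogen in place of bromo on an aromatic carbon).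

Going by the values given here, two measured steps bear on this change. The closest is bromo in place of chloro on an aromatic carbon, a modest step (a 2.2-fold higher number from compound 1 to compound 2 (0.35 log units; beyond the scatter)). The other is large (a 10-fold lower number from compound 2 to compound 3 (1.01 log units; beyond the scatter)), but it brings in 5-bromo-2-chlorophenyl in place of 4-bromophenyl, so it says little about simply removing a bromo group. Among the compounds with values here, no measured compound lacks a halogen on this ring, which leaves the outcome uncertain.

With compound 1 lower than compound 2 (a 2.2-fold higher number from compound 1 to compound 2 (0.35 log units; beyond the scatter)), a small move towards a lower number is expected in this assay, and it may not exceed the scatter. The step expected is small (estimated: a 1.4-fold lower number from compound 2 to compound 4 (0.16 log units; within the scatter)). The estimated value for compound 4 is modest in strength (18 ug/mL, expected range 7 ug/mL to 45 ug/mL).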

Compound 4, concentration for 50% growth inhibition: 10.4 ug/mL
Compound 4: middle estimate off by 1.7-fold (0.24 log units), on the high side, and the stated range covers the measured number.
By their numbers in this assay, from the lowest: compound 3; then compounds 4 and 1 (each within the scatter of the next); then compound 2.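

In this assay, taking the bromo group off the aromatic carbon para to a large group lowers the number, a 2.5-fold lower number from compound 2 to compound 4 (0.39 log units; beyond the scatter), so bromo at this position is not needed for growth inhibition and the plain phenyl ring does better than 4-bromophenyl. Hydrogen and chloro at the same position cannot be told apart, a 1.1-fold lower number from compound 1 to compound 4 (0.05 log units; within the scatter), so among these three groups only bromo stands out, with the weakest growth inhibition. A halogen at this position is therefore not required, but halogens elsewhere may still matter: going from 5-bromo-2-chlorophenyl to phenyl gives a 4.2-fold higher number from compound 3 to compound 4 (0.62 log units; beyond the scatter), which leaves compound 3 with the lowest number of the set.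

Nothing available here explains why bromo behaves differently from chloro and hydrogen at this position. Still open, on these data alone, are how a methoxy group or an amine would behave in place of bromo, and whether the chloro, the bromo or the two together account for the lower number of the 5-bromo-2-chlorophenyl compound.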